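Thiosemicarbazones of a Quinoline Aldehyde: Aryl Swap Considered

A few compounds are considered here, and "the series" means these few. Any claim that something is new, unique, unknown or untested is made for them only; others in the source may bear on it.

Compound 1 `N#Cc1ccc(NC(=S)N/N=C/c2ccc3ccccc3n2)cc1` and compound 2 `S=C(N/N=C/c1ccc2ccccc2n1)Nc1ccc(Cl)cc1` share one core and differ only in the group on the aromatic ring attached to the thiourea nitrogen. In a functional assay on SGC-7901 cells (Homo sapiens) for antiproliferative activity, read by sulforhodamine B assay, with a stated time of 72 h (a lower number here means a stronger inhibitor, a higher number a weaker inhibitor), compound 1 gives 23700 nM, and compound 2 gives 87600 nM, the higher of the two numbers; the change is a 3.7-fold higher number from compound 1 to compound 2 (0.57 log units; beyond the scatter). Compound 3 `Cc1ccccc1NC(=S)N/N=C/c1ccc2ccccc2n1` is made from compound 2 by 2-methylphenyl in place of 4-chlorophenyl on an amide-type nitrogen. Among the compounds with values here, no measured step involves this kind of exchange; the single step seen, from compound 1 to compound 2, concerns a different substituent and offers no direct guide. A step from compound 2 to compound 3 of a 1.3-fold lower number from compound 2 to compound 3 (0.10 log units; within the scatter) in this assay is therefore expected, with little confidence in its direction. On that basis compound 3 is estimated at 70000 nM in this assay, in a range from 20000 nM to 200000 nM.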

Compound 3, half-maximal inhibitory concentration: > 100000 nM
Compound 3 ended at the assay's limit; the forecaster's own chance of this, stated with the estimate: 15%; at least 1.4-fold (0.15 log units) between middle value and limit.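

In this assay compound 3 gives > 100000 nM, which is a limit of the assay and not a number. Replacing 4-cyanophenyl with 2-methylphenyl on the amide-type nitrogen gives a readable result, an at least 4.2-fold higher number from compound 1 to compound 3 (0.62 log units; beyond the scatter), so compound 1 holds the lowest number of the three, with its steps to both others beyond the scatter. Replacing 4-chlorophenyl with 2-methylphenyl gives only an at least 1.1-fold higher number from compound 2 to compound 3 (0.05 log units; that floor lies within the scatter), and whether these two groups truly differ at this nitrogen stays undecided because the value of compound 3 is hidden by the assay's ceiling: the limit of > 100000 nM in this assay, at which 1 of the 3 values shown sits.

The compounds shown leave open how an amine or a carboxylic acid on this aromatic ring would read in this assay. They also leave open whether any such group would give a lower number than compound 1.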